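The source may hold more compounds than are shown below. What is called first, only, known or untested is meant among the compounds shown, and "the series" means these compounds.

Compound 3 `CC(=O)OC[C@H]1O[C@@H](n2cc(CN3C(=O)/C(=C\c4ccc(N(C)C)cc4)c4ccccc43)nn2)[C@H](OC(C)=O)[C@@H](OC(C)=O)[C@@H]1OC(C)=O` belongs to a set of three analogues that share one core and differ only in the aryl group on the exocyclic double bond. In a functional assay on A549 cells (Homo sapiens) for cytotoxicity, read by sulforhodamine B assay, with a stated time of 48 h (a lower number here means a stronger inhibitor, a higher number a weaker inhibitor), compound 3 gives 17700 nM, a number that sits within the scatter of both its companions: compound 1 `CC(=O)OC[C@H]1O[C@@H](n2cc(CN3C(=O)/C(=C\c4ccc(C)cc4)c4ccccc43)nn2)[C@H](OC(C)=O)[C@@H](OC(C)=O)[C@@H]1OC(C)=O` gives 16500 nM and compound 2 `COc1ccc(/C=C2\C(=O)N(Cc3cn([C@@H]4O[C@H](COC(C)=O)[C@@H](OC(C)=O)[C@H](OC(C)=O)[C@H]4OC(C)=O)nn3)c3ccccc32)cc1OC` gives 23300 nM. The change leading to compound 4 `CC(=O)OC[C@H]1O[C@@H](n2cc(CN3C(=O)/C(=C\c4ccc5ccccc5c4)c4ccccc43)nn2)[C@H](OC(C)=O)[C@@H](OC(C)=O)[C@@H]1OC(C)=O` is naphthalen-2-yl in place of 4-(dimethylamino)phenyl on a double-bonded chain carbon bound to a double-bonded ring carbon. The measured steps among these aryl groups were a 1.1-fold higher number from compound 1 to compound 3 (0.03 log units; within the scatter), a 1.4-fold higher number from compound 1 to compound 2 (0.15 log units; within the scatter) and a 1.3-fold lower number from compound 2 to compound 3 (0.12 log units; within the scatter), each within the scatter. Among the compounds with values here, no measured compound carries a fused two-ring aryl group, so the step of a 1.0-fold higher number from compound 3 to compound 4 (0.01 log units; within the scatter) is expected to stay within the scatter. Compound 4 is therefore estimated at 18000 nM, with a range from 9000 nM to 36000 nM.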

Compound 4, half-maximal inhibitory concentration: 62200 nM
The estimate for compound 4 lay 3.5-fold (0.54 log units) below the measured number; the whole stated range lies below it.
By their numbers in this assay, from the lowest: compounds 1, 3 and 2 (each within the scatter of the next); then compound 4.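

At this position, on a double-bonded chain carbon bound to a double-bonded ring carbon, the three single-ring aryl groups had given numbers within the scatter of one another in this assay. Naphthalen-2-yl is the first group to move the number beyond the scatter, and it does so against all three (a 3.5-fold higher number from compound 3 to compound 4 (0.55 log units; beyond the scatter); a 2.7-fold higher number from compound 2 to compound 4 (0.43 log units; beyond the scatter); a 3.8-fold higher number from compound 1 to compound 4 (0.58 log units; beyond the scatter)), so the position does respond to the aryl group, with the change here towards weaker inhibition. No evidence is available to explain this step. On these data alone, this reading rests on compound 4 alone, and whether naphthalen-1-yl or biphenyl-4-yl would behave the same way remains open.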